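This account rests on a few compounds, and the source may have more. Where it says the series, first, only, none or still open, it means among the compounds named here.

Series notes. In an assay on isolated protein for antagonist activity at Voltage-dependent L-type calcium channel subunit alpha-1C (Cavia porcellus), with a stated time of 15 min (on this read-out lower numbers stand for stronger inhibition and higher numbers for weaker inhibition), compound 1 `CC1=C(C(=O)OC(C)(C)C)C(c2csc(-c3ccc(Cl)cc3)n2)C(C(=O)OC(C)(C)C)=C(C)N1` gives 21000 nM, and compound 2 `CC1=C(C(=O)OC(C)c2ccccc2)C(c2csc(-c3ccc(Cl)cc3)n2)C(C(=O)OC(C)c2ccccc2)=C(C)N1` gives 400000 nM, the higher of the two numbers, with a gap beyond the usual scatter. Compound 3 `COC(=O)C1=C(C)NC(C)=C(C(=O)OC(C)c2ccccc2)C1c1csc(-c2ccc(Cl)cc2)n1` is not yet measured in this assay. Its difference from compound 2 is methyl in place of 1-phenylethyl on an oxygen next to a carbonyl group. Compound 3 keeps one 1-phenylethyl ester of compound 2 and takes a methyl ester on the other side. Given that compound 2 gives 400000 nM and compound 1 gives 21000 nM, a step downward beyond the scatter is expected in this assay, estimated as a 20-fold lower number from compound 2 to compound 3 (1.30 log units; beyond the scatter). Compound 3 is therefore expected at 20000 nM, within 4000 nM to 100000 nM.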

Compound 3, half-maximal inhibitory concentration: 7620 nM
Compound 3: the middle estimate sits 2.6-fold (0.42 log units) above what was measured; the measured number falls inside the stated range.
By their numbers in this assay, from the lowest: compound 3; then compound 1; then compound 2.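

In this assay, methyl in place of 1-phenylethyl on an oxygen next to a carbonyl group gives a 52-fold lower number from compound 2 to compound 3 (1.72 log units; beyond the scatter) and this step is large. A change at one ester alone, with the other 1-phenylethyl ester kept, is thus enough to move this read-out strongly, whereas compound 1 and compound 2 differ at both esters. Nothing at hand accounts for the size of this step.

Still open, going by these compounds, is whether an ethyl or a benzyl ester at this place behaves like methyl or like 1-phenylethyl. Also open, on these data alone, is how a carboxylic acid or an amide at this place would read.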